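Compound 3 to compound 4: working notes

The source may hold more compounds than are shown below. What is called first, only, known or untested is meant among the compounds shown, and "the series" means these compounds.

- compound 1 `COc1ccc(C(=O)/C=C/c2ccc(N3CCCC3)cc2)c2c1C=CC(C)(C)O2`: 7150 nM
- compound 2 `COc1ccc(C(=O)/C=C/c2ccc(C(F)(F)F)cc2)c2c1C=CC(C)(C)O2`: > 10000 nM (a limit)
- compound 3 `COc1ccc(C(=O)/C=C/c2cccc(Cl)c2)c2c1C=CC(C)(C)O2`: > 10000 nM (a limit)

In a functional assay on SW-620 cells (Homo sapiens) for antiproliferative activity, read by MTT assay, with a stated time of 24 h (on this read-out higher numbers stand for weaker inhibition and lower numbers for stronger inhibition), compound 3 gives > 10000 nM, which is a limit and not a number. Compound 2 gives > 10000 nM, also a limit. For the measured compounds named here, the series so far is thus marked by the limit of > 10000 nM in this assay, at which 2 of the 3 values shown sit.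

Compound 4 `COc1ccc(C(=O)/C=C/c2ccc(O)cc2)c2c1C=CC(C)(C)O2` carries 4-hydroxyphenyl in place of 3-chlorophenyl on a double-bonded chain carbon bound to a double-bonded chain carbon.

Going by the values given here, the only measured step is an at least 1.3-fold higher number from compound 1 to compound 2 (0.14 log units; that floor lies within the scatter). It involves neither group of this change, so it bears only loosely and sets no size. Among the compounds with values here, compound 1, at 7150 nM, holds the only number and is the sole anchor for a measurable value. Only a small move toward a lower number is expected in this assay, with nothing clearly beyond the scatter. For compound 4 the expected step is an at least 1.1-fold lower number from compound 3 to compound 4 (0.04 log units; that floor lies within the scatter). Compound 4 is estimated at 9000 nM, with an expected range of 3500 nM to 20000 nM.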

Compound 4, half-maximal inhibitory concentration: > 10000 nM
Compound 4 gave a limit, no number; the forecaster's own chance of this, stated with the estimate: 50%; middle value at least 1.1-fold (0.04 log units) from the limit.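

In this assay compound 4 gives > 10000 nM, which is a limit and not a number; a hydrogen-bond donor and acceptor on the 4-hydroxyphenyl therefore yield no number here, just as 3-chlorophenyl and the trifluoromethyl-bearing ring yield none, and only the pyrrolidin-1-yl of compound 1 goes against this pattern. For the compounds shown here, the one readable step is an at least 1.3-fold higher number from compound 1 to compound 4 (0.14 log units; that floor lies within the scatter), and the steps between the limits cannot be read. The series now stands as follows: the limit of > 10000 nM in this assay, at which 3 of the 4 values shown sit.

Going by these compounds, it remains open whether a number at this position goes with the amine nitrogen of pyrrolidin-1-yl or with that ring as a whole. A dimethylamino group, a piperidine or a morpholine on the same aromatic carbon would separate these, and a carboxylic acid there remains an open case.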